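A few compounds are considered here, and "the series" means these few. Any claim that something is new, unique, unknown or untested is made for them only; others in the source may bear on it.

Measured in an in vitro ADME assay on microsomes from liver (Rattus norvegicus) for metabolic stability, tested at 2 uM; a higher number here means that the compound lasts longer, a lower number that the compound disappears faster:
compound 1 `C#Cc1ccc(NC(=O)CSc2nnnn2-c2ccc(C3CC3)cc2Cl)c(Cl)c1` gives 0.0667 h;
compound 2 `O=C(CSc1nnnn1-c1ccc(C2CC2)cc1Cl)Nc1ccc(C#CCO)cc1Cl` gives 0.117 h;
compound 3 `CC(C)(C#Cc1ccc(NC(=O)CSc2nnnn2-c2ccc(C3CC3)cc2Cl)c(Cl)c1)OCC(=O)O` gives 0.483 h.

Compound 3 stands highest of the three, with a 7.2-fold higher number from compound 1 to compound 3 (0.86 log units; beyond the scatter) and a 4.1-fold higher number from compound 2 to compound 3 (0.62 log units; beyond the scatter), while a 1.8-fold higher number from compound 1 to compound 2 (0.24 log units; within the scatter) is within the scatter. Compound 4 `CC(C)(C#Cc1ccc(NC(=O)CSc2nnnn2-c2ccc(C3CC3)cc2Cl)c(Cl)c1)CC(=O)O` differs from compound 3 in one place: carboxymethyl in place of carboxymethoxy on a saturated chain carbon bound to two saturated chain carbons and a triple-bonded carbon. Among the compounds with values here, no measured step touches this part of the chain; the measured steps only exchange the whole group on the triple-bonded carbon, and the two steps that lead to compound 3 point the same way. A change this small is therefore expected to give a step within the scatter, in no particular direction. For compound 4 a value of 0.4 h is estimated, between 0.15 h and 1 h, that is a 1.2-fold lower number from compound 3 to compound 4 (0.08 log units; within the scatter) as the expected step.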

Compound 4, half-life: 0.35 h
Compound 4: the middle estimate sits 1.1-fold (0.06 log units) above what was measured; measured number inside the range.
By their numbers in this assay, from the lowest: compounds 1 and 2 (each within the scatter of the next); then compounds 4 and 3 (each within the scatter of the next).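

In this assay, carboxymethyl in place of carboxymethoxy on the saturated chain carbon gives a 1.4-fold lower number from compound 3 to compound 4 (0.14 log units; within the scatter) and so the chain oxygen can go without a step beyond the scatter. The larger group with carboxymethyl also stands apart from the smaller groups on the triple-bonded carbon, with a 3.0-fold higher number from compound 2 to compound 4 (0.48 log units; beyond the scatter) and a 5.2-fold higher number from compound 1 to compound 4 (0.72 log units; beyond the scatter) and so the gain is not tied to carboxymethoxy alone. No measurement here explains these steps. From the compounds shown here alone, what an amine or a longer chain in place of carboxymethyl would give stays open.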